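The source may report more compounds than this note shows. Statements on the series, on what has been measured and on what is new or still open speak of the compounds shown alone.

Measured in an assay on HEK293 cells for agonist activity at transient receptor potential cation channel subfamily M member 8 (Homo sapiens), read by fluorescence and calcium flux, with a stated time of 15 min; a higher number here means that more compound is needed for the effect, a lower number that less compound is needed:
compound 1 `Cc1ccc(OCC(=O)N(Cc2cccs2)CC(C)C)cc1` gives 900 nM
compound 2 `CCN(Cc1c[nH]nn1)C(=O)COc1ccc(C)cc1` gives 31100 nM
compound 3 `CCN(Cc1cccs1)C(=O)COc1ccc(C(F)(F)F)cc1` gives 236 nM

Among these three, compound 1 holds the second highest number. Compound 3 stands nearest to it, with a lower number, and that gap lies beyond the scatter; compound 2 stands furthest, with a far higher number, also beyond the scatter.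

Compound 4 `Cc1ccc(OCC(=O)N(Cc2cccs2)c2ccccn2)cc1` has not yet been measured in this assay. It differs from compound 1 in one place: pyridin-2-yl in place of isobutyl on an amide-type nitrogen. Going by the values given here, no measured pair here shows a change of this kind, so the expectation rests on little. A small step toward a higher number, or none beyond the scatter, is expected, as a 1.7-fold higher number from compound 1 to compound 4 (0.22 log units; within the scatter). Compound 4 is estimated at 1500 nM, within 300 nM to 8000 nM.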

Compound 4, half-maximal effective concentration: 200 nM
For compound 4 the middle estimate is 7.5-fold (0.88 log units) above the measured one; the whole stated range lies above it.
By their numbers in this assay, from the lowest: compounds 4 and 3 (each within the scatter of the next); then compound 1; then compound 2.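

Putting pyridin-2-yl in place of isobutyl on the amide-type nitrogen gives a 4.5-fold lower number from compound 1 to compound 4 (0.65 log units; beyond the scatter) in this assay. This position therefore accepts an aromatic ring with a hetero atom in place of a saturated chain, and the number falls rather than rises. Nothing shown here accounts for this fall.

As far as these compounds go, whether the ring nitrogen matters remains open, as a plain phenyl or a cyclohexyl on this nitrogen would be needed to tell. Also open, from the compounds shown here alone, is whether the step would hold with trifluoromethyl on the shared core.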